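Carbamate chain length in a selenocyanate series: compound 4

The compounds below may be only part of what the source reports. "The series", "measured", "known", "first", "only" and "open" are said of these compounds alone.

Measured so far in a functional assay on HTB-54 cells (Homo sapiens) for cytotoxicity, read by MTT assay, with a stated time of 72 h; a lower number here means a stronger inhibitor of growth, a higher number a weaker inhibitor of growth:
compound 1, `CCOC(=O)Nc1ccc([Se]C#N)cc1`, gives 49300 nM
compound 2, `CCOC(=O)Nc1ccc([Se][Se]c2ccc(NC(=O)OCC)cc2)cc1`, gives 56600 nM
compound 3, `O=C(Nc1ccc([Se][Se]c2ccc(NC(=O)OCc3ccccc3)cc2)cc1)OCc1ccccc1`, gives 50900 nM

Compound 1 carries the lowest of the three numbers, but its nearest neighbour, compound 3, sits within the scatter of it, and so does compound 2, the furthest. Among the compounds with values here, on these numbers the three compounds are indistinguishable; no compound can be called stronger or weaker than another, and the change from the selenocyanate of compound 1 to either diselenide brings nothing beyond the scatter.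

The next compound, compound 4, `CCCCCCOC(=O)Nc1ccc([Se]C#N)cc1`, keeps the selenocyanate of compound 1 and differs from it only in the carbamate ester: butyl in place of hydrogen on a saturated chain carbon, two bonds along the chain from an oxygen next to a carbonyl group. Within the data shown here, no pair of measured compounds differs in one place, so no measured step guides this change. With all three measured numbers sitting together in this assay, the expectation for compound 4 is a step of a 1.4-fold lower number from compound 1 to compound 4 (0.15 log units; within the scatter), small and not clearly beyond the scatter, leaning slightly toward a lower number. Compound 4 is therefore estimated at 35000 nM, with a range from 12000 nM to 100000 nM.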

Compound 4, concentration for total growth inhibition: 48500 nM
Compound 4: middle estimate off by 1.4-fold (0.14 log units), on the low side, and the stated range covers the measured number.
By their numbers in this assay, from the lowest: compounds 4, 1, 3 and 2 (each within the scatter of the next).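

In this assay the series now has its first one-place step, and it falls at the carbamate ester: butyl in place of hydrogen on a saturated chain carbon, two bonds along the chain from an oxygen next to a carbonyl group, gives (a 1.0-fold lower number from compound 1 to compound 4 (0.01 log units; within the scatter)). The earlier compounds shown here could say nothing about this position, since none of them differed in one place; this step shows that, with the selenocyanate kept, going from ethyl to hexyl produces no change that can be told from the scatter, so this position accepts the added butyl with neither gain nor loss in this read-out. No measurement in hand bears on why the step is so small.

A single chain extension leaves open whether the flat reading holds for a longer chain such as decyl, or for a chain ending in an amine or a carboxylic acid. Within the data shown here, it also leaves open whether hexyl behaves the same way on a diselenide, where no one-place step is available yet.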